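A pyridin-4-yl exchange at one aromatic carbon

The source may report more compounds than this note shows. Statements on the series, on what has been measured and on what is new or still open speak of the compounds shown alone.

In an ADME assay (liver) for metabolic stability, with Liver microsome (Rattus norvegicus) as the target, using microsomes and NADPH, with a stated time of 30 min, tested at 1 uM (on this read-out higher numbers stand for fast clearance and lower numbers for slow clearance), compound 1 `Nc1ccc(S(=O)(=O)N2CCN(c3ncc(C(O)(C(F)(F)F)C(F)(F)F)cc3C#CCO)CC2)cn1` gives 65 mL.min-1.g-1 and compound 2 `CS(=O)(=O)c1ccc(-c2cc(C(O)(C(F)(F)F)C(F)(F)F)cnc2N2CCN(S(=O)(=O)c3ccc(N)nc3)CC2)cc1` gives 103 mL.min-1.g-1. Among the measured compounds shown here, these are the only two numbers so far, and they lie within the scatter of each other, so compound 2 cannot be told apart from compound 1 on this read-out.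

Compound 3 `Nc1ccc(S(=O)(=O)N2CCN(c3ncc(C(O)(C(F)(F)F)C(F)(F)F)cc3-c3ccncc3)CC2)cn1` follows from compound 2 through a single exchange: pyridin-4-yl in place of 4-(methylsulfonyl)phenyl on an aromatic carbon. It places pyridin-4-yl in place of 4-(methylsulfonyl)phenyl on an aromatic carbon, at the same carbon that separates compound 1 from compound 2.

For the measured compounds named here, one measured step bears on this exchange: a 1.6-fold higher number from compound 1 to compound 2 (0.20 log units; within the scatter). That step brought in 4-(methylsulfonyl)phenyl in place of 3-hydroxyprop-1-yn-1-yl and stayed within the scatter. Going by the values given here, no measured compound yet carries pyridin-4-yl, so this single small step is the only guide, and it gives no direction. No step beyond the scatter is therefore expected in this assay. The expected step is a 1.3-fold lower number from compound 2 to compound 3 (0.11 log units; within the scatter). For compound 3 the estimated value is 80 mL.min-1.g-1, with an expected range of 40 mL.min-1.g-1 to 160 mL.min-1.g-1.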

Compound 3, intrinsic clearance in microsomes: 31 mL.min-1.g-1
Beside the measured number, compound 3's estimate is 2.6-fold (0.41 log units) above it, and the stated range ends above it.
By their numbers in this assay, from the lowest: compound 3; then compounds 1 and 2 (each within the scatter of the next).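

In this assay, the earlier exchange at this carbon, a 1.6-fold higher number from compound 1 to compound 2 (0.20 log units; within the scatter), did not show that the read-out responds to the group placed here, whereas a 3.3-fold lower number from compound 2 to compound 3 (0.52 log units; beyond the scatter) shows that it does when pyridin-4-yl replaces 4-(methylsulfonyl)phenyl. The response is not confined to that one pair: a 2.1-fold lower number from compound 1 to compound 3 (0.32 log units; beyond the scatter) also lies beyond the scatter, so among the three groups seen at this position, two ortho to a large group and meta to the 2,2,2-trifluoro-1-hydroxy-1-(trifluoromethyl)ethyl group being compared at a time, pyridin-4-yl alone stands apart, while 3-hydroxyprop-1-yn-1-yl and 4-(methylsulfonyl)phenyl cannot be separated. No measurement at hand accounts for this difference.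

The compounds shown leave open whether the lower number goes with the ring nitrogen of pyridin-4-yl or with the departure of the methylsulfonyl group, a question that an unsubstituted phenyl at this carbon would address. As far as these compounds go, it is also open whether the placing of that nitrogen counts, which a pyridin-3-yl or pyridin-2-yl group at the same carbon would test.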